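The source may report more compounds than this note shows. Statements on the series, on what has been measured and on what is new or still open speak of the compounds shown alone.

Three compounds share one core and differ only in the side group on the aromatic ring. Compound 1 `CC(=O)N1CCC(Oc2cncc(N3C(=O)c4ccc(Cl)cc4C3(C)C)c2)CC1` carries a 1-acetylpiperidin-4-yl group on an oxygen on an aromatic ring; in an assay on cells for inhibition of cytochrome P450 11B2, mitochondrial (Homo sapiens), read by HTRF (a higher number here means a weaker inhibitor, a lower number a stronger inhibitor), compound 1 gives 4 nM. Compound 2 `CC(=O)N1CC[C@@H](Oc2cncc(N3C(=O)c4ccc(Cl)cc4C3(C)C)c2)C1` has 1-acetylpyrrolidin-3-yl in that place, and in this assay compound 2 gives 11 nM, the highest number of the three, so it is the weakest inhibitor shown. Compound 3 `CCS(=O)(=O)N1CC(Oc2cncc(N3C(=O)c4ccc(Cl)cc4C3(C)C)c2)C1` carries a four-membered ring bearing an ethylsulfonyl group; compound 3 gives 4 nM. The steps are modest: a 2.8-fold higher number from compound 1 to compound 2 (0.44 log units; beyond the scatter), a 2.8-fold lower number from compound 2 to compound 3 (0.44 log units; beyond the scatter), while no change at the digits printed from compound 1 to compound 3 (within the scatter).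

Compound 4 `CCS(=O)(=O)NCc1cncc(N2C(=O)c3ccc(Cl)cc3C2(C)C)c1` has not yet been measured. The change from compound 2 is a group of 7 heavy atoms (3 carbon, 1 nitrogen, 2 oxygen, 1 sulfur; no ring) in place of a group of 9 heavy atoms (6 carbon, 1 nitrogen, 2 oxygen; one five-membered non-aromatic ring with 1 hetero atom), on an aromatic carbon. The ring and the oxygen link are gone, and a short chain brings in the ethylsulfonyl group also found in compound 3. For the measured compounds named here, the step from compound 2 to compound 3 shows that bringing in ethylsulfonyl can lower the number, but no measured step removes the ring, so the guidance is loose. For compound 4 the expected value is 15 nM, with a range from 4 nM to 60 nM. The expected step is a 1.4-fold higher number from compound 2 to compound 4 (0.13 log units; within the scatter), likely no more than modest in either direction.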

Compound 4, half-maximal inhibitory concentration: 92 nM
Beside the measured number, compound 4's estimate is 6.1-fold (0.79 log units) below it; the whole stated range lies below it.
By their numbers in this assay, from the lowest: compounds 1 and 3 (each within the scatter of the next); then compound 2; then compound 4.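

For the compounds shown here, this is the first change here that removes both the ring and the oxygen link, and it gives a larger step than any swap of one ring for another: an 8.4-fold higher number from compound 2 to compound 4 (0.92 log units; beyond the scatter) in this assay on the same shared core. The ethylsulfonyl group does not by itself secure a low number, since compound 3 carries it at 4 nM and compound 4 carries it at 92 nM in a different setting. The change also adds a hydrogen-bond donor, so several things shift at once, and nothing measured here accounts for the step.

Which of these parts matters most remains open. A simple ethoxy chain on the oxygen, with no ring, or an amine in place of the ethylsulfonyl group could help separate them.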